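From compound 2 to compound 4: adding chloro

This account rests on a few compounds, and the source may have more. Where it says the series, first, only, none or still open, it means among the compounds named here.

Measured in a functional assay on HCT-116 cells (Homo sapiens) for cytotoxicity, read by sulforhodamine B assay, with a stated time of 48 h; on this read-out higher numbers stand for weaker inhibition and lower numbers for stronger inhibition:
- compound 1 `O=S(=O)(c1ccccc1)c1cnc2cc(-c3ccc(Cl)cc3)nn2c1-c1ccccc1`: 1.64 ug/mL
- compound 2 `Cc1ccc(-c2c(S(=O)(=O)c3ccccc3)cnc3cc(-c4ccccc4)nn23)cc1`: 18 ug/mL
- compound 3 `Cc1ccc(-c2c(S(=O)(=O)c3ccccc3)cnc3c(Br)c(-c4ccccc4)nn23)cc1`: 14 ug/mL

Compound 2, at 18 ug/mL, sits within the scatter of compound 3 and beyond the scatter from compound 1, whose number is lower. Compound 4 `Cc1ccc(-c2c(S(=O)(=O)c3ccccc3)cnc3cc(-c4ccc(Cl)cc4)nn23)cc1` changes phenyl to 4-chlorophenyl, with chloro in place of hydrogen on an aromatic carbon.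

Among the compounds with values here, the only measured single-place step, a 1.3-fold lower number from compound 2 to compound 3 (0.11 log units; within the scatter), puts bromo at another place and offers little guidance. Within the data shown here, compound 1 also bears 4-chlorophenyl and gives 1.64 ug/mL, although no measured step isolates that group. A moderate move towards stronger inhibition in this assay is therefore expected, with the estimated step being a 3.6-fold lower number from compound 2 to compound 4 (0.56 log units; beyond the scatter). The estimate for compound 4 is 5 ug/mL, with an expected range of 1.5 ug/mL to 16 ug/mL.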

Compound 4, half-maximal inhibitory concentration: 9.3 ug/mL
Compound 4: the middle estimate sits 1.9-fold (0.27 log units) below what was measured; the measured number falls inside the stated range.
By their numbers in this assay, from the lowest: compound 1; then compounds 4, 3 and 2 (each within the scatter of the next).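

In this assay, 4-chlorophenyl in place of phenyl gives only a step within the scatter (a 1.9-fold lower number from compound 2 to compound 4 (0.29 log units; within the scatter)), so chloro at this place shows no clear change on its own. With 4-chlorophenyl held constant, methyl in place of hydrogen gives a step beyond the scatter (a 5.7-fold higher number from compound 1 to compound 4 (0.75 log units; beyond the scatter)), the larger of the two. Nothing available bears on the cause of either step.

From the compounds shown here alone, it remains open whether the methyl step holds when phenyl replaces 4-chlorophenyl. Also open, going by these compounds, is whether a methoxy group or an amine in place of chloro would give a step beyond the scatter.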